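The source may hold more compounds than are shown below. What is called first, only, known or untested is meant among the compounds shown, and "the series" means these compounds.

Measured so far:
compound 1, `Nc1nc(Cl)c2nnn([C@H]3CCCC[C@H]3CO)c2n1` — 95500 nM
compound 2, `CC(C)(C)C#Cc1cn([C@@H]2O[C@H](CO)[C@@H](O)[C@@H]2O)c(=O)[nH]c1=O` — > 200000 nM

Within the data shown here, in an ADME assay on L1210/0 cells (Mus musculus) for cytotoxicity, with a stated time of 48 h (a higher number here means a weaker inhibitor, a lower number a stronger inhibitor), compound 1 gives 95500 nM, the only number reported. For compound 2 the result is a limit only, > 200000 nM, so it is not a number that can be ordered against compound 1; this matches (the limit of > 200000 nM in this assay, at which 1 of the 2 values shown sits). Compound 3, `Nc1nc(O)c2nnn([C@H]3CCCC[C@H]3CO)c2n1`, has not yet been tested in this assay. It differs from compound 1 by hydroxy in place of chloro on an aromatic carbon. Among the measured compounds shown here, no measured pair shows what such a change does here, so the expected step is estimated as a 1.3-fold higher number from compound 1 to compound 3 (0.10 log units; within the scatter), a move not clearly beyond the scatter. Compound 3 is expected to give 120000 nM, between 30000 nM and 400000 nM.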

Compound 3, half-maximal inhibitory concentration: > 200000 nM
Compound 3: only a limit was reported; the forecaster's own chance of this, stated with the estimate: 40%; middle value at least 1.6-fold (0.22 log units) from the limit.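

In this assay, among these compounds, hydroxy in place of chloro on the aromatic carbon gives an at least 2.0-fold higher number from compound 1 to compound 3 (0.32 log units; beyond the scatter), the first measured change at this position and one beyond the scatter. On these data alone, the result for compound 3 is a limit, so the full size of the step stays unknown. Among the compounds shown here, compound 1 remains the only compound with a number: the limit of > 200000 nM in this assay, at which 2 of the 3 values shown sit.

The compounds shown leave open whether an amine, a methoxy or a bromo on this carbon would give a number in this assay. They also leave open how far the chloro of compound 1 can be varied while a number is retained.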